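A few compounds are considered here, and "the series" means these few. Any claim that something is new, unique, unknown or untested is made for them only; others in the source may bear on it.

Within the data shown here, compound 2 `C[C@@H]1CCCN1c1c(C#N)c2c(N)ncnc2n1C` gives 15 nM in an assay on isolated protein for inhibition of Leucine-rich repeat serine/threonine-protein kinase 2 (Homo sapiens), read by TR-FRET and LanthaScreen, with stated times of 50 min and 30 min, in the presence of a further agent that is not named here (on this read-out lower numbers stand for stronger inhibition and higher numbers for weaker inhibition), the lowest of the three numbers measured so far: compound 1 `CN(C)c1c(C#N)c2c(N)ncnc2n1C` gives 4620 nM and compound 3 `C[C@@H]1CCCN1c1cc2c(N)ncnc2n1C` gives 6830 nM. The steps of a 310-fold lower number from compound 1 to compound 2 (2.49 log units; beyond the scatter) and a 460-fold higher number from compound 2 to compound 3 (2.66 log units; beyond the scatter) are both large, but each concerns a different part of the shared core. Compound 4 `Cc1nn(C)cc1Nc1nc(N)c2c(C#N)c(N3CCC[C@H]3C)n(C)c2n1` differs from compound 2 by (1,3-dimethyl-1H-pyrazol-4-yl)amino in place of hydrogen on an aromatic carbon. Among the measured compounds shown here, no measured step touches this position, so the expectation rests on compound 2 alone and carries wide uncertainty. Compound 4 is therefore expected to give about 6 nM in this assay, within a range of 1 nM to 40 nM. This corresponds to an expected step of a 2.5-fold lower number from compound 2 to compound 4 (0.40 log units; beyond the scatter), which may or may not lie beyond the scatter.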

Compound 4, half-maximal inhibitory concentration: 38 nM
For compound 4 the middle estimate is 6.3-fold (0.80 log units) below the measured one; the range from low to high includes it.
By their numbers in this assay, from the lowest: compound 2; then compound 4; then compounds 1 and 3 (each within the scatter of the next).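

In this assay, among these compounds, the position between two ring nitrogen atoms tolerates a substantial addition: (1,3-dimethyl-1H-pyrazol-4-yl)amino, with 8 heavy atoms, gives only a modest change, a 2.5-fold higher number from compound 2 to compound 4 (0.40 log units; beyond the scatter), whereas the earlier steps at the other two places were large. Adding this group at this position therefore weakens inhibition slightly, but does not abolish it. No evidence is available on why the step has this size. Going by these compounds, what a plain amino group, a methylamino group or a pyrazolylamino group lacking the two methyl groups would give here remains open.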